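A Branched Chain in Place of a Straight One

The source may hold more compounds than are shown below. What is called first, only, known or untested is meant among the compounds shown, and "the series" means these compounds.

Compound 1 `CCCCNC(=O)c1ccccc1[Se][Se]c1ccccc1C(=O)NCCCC` gives, in a functional assay on DU-145 cells (Homo sapiens) for cytotoxicity, read by sulforhodamine B assay, with a stated time of 24 h (on this read-out lower numbers stand for stronger inhibition and higher numbers for weaker inhibition), only a limit of > 40000 nM. Compound 1 thus accounts for (the limit of > 40000 nM in this assay, at which 1 of the 2 values shown sits). Within the data shown here, compound 2 `CCCCn1[se]c2ccccc2c1=O` gives in this assay a value of 20800 nM, the only actual number among the two results so far. Compound 3 `CC(C)CCn1[se]c2ccccc2c1=O` carries methyl in place of hydrogen on a saturated chain carbon bound to two saturated chain carbons. Among the measured compounds shown here, with no measured step between related compounds to draw on, the change is expected to stay within the usual scatter, so the step is estimated as a 1.2-fold lower number from compound 2 to compound 3 (0.06 log units; within the scatter). Compound 3 is therefore expected near 18000 nM in this assay, from 7000 nM to 45000 nM.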

Compound 3, half-maximal inhibitory concentration: 30400 nM
Estimate against measurement, compound 3: 1.7-fold (0.23 log units) below; the range from low to high includes it.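

In this assay, among these compounds, the first measured step on this chain, butyl to isopentyl, is a 1.5-fold higher number from compound 2 to compound 3 (0.16 log units; within the scatter) and so leaves compound 2 and compound 3 indistinguishable. A methyl in place of hydrogen on a saturated chain carbon bound to two saturated chain carbons therefore makes no readable difference here. Nothing shown bears on the reason for this result.

On these data alone, whether a longer chain would shift the number remains open. So does the effect of an amine or a carboxylic acid on this chain.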